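Replacing the lactam ring with a methylpiperazine

This account rests on a few compounds, and the source may have more. Where it says the series, first, only, none or still open, it means among the compounds named here.

Two compounds share a core carrying two chlorophenyl rings, an amino group and an amide. Compound 1 `Nc1sc(-c2ccc(Cl)cc2)c(-c2ccc(Cl)cc2)c1C(=O)N1CCCCC1` bears a piperidin-1-yl on the carbonyl carbon; in a functional assay on PC-3 cells (Homo sapiens) for inhibition, read by sulforhodamine B assay, with a stated time of 72 h (a higher number here means a weaker inhibitor, a lower number a stronger inhibitor), compound 1 gives 14300 nM. Compound 2 `Nc1sc(-c2ccc(Cl)cc2)c(-c2ccc(Cl)cc2)c1C(=O)N1CCCCC1=O` carries a 2-oxopiperidin-1-yl there, and in this assay compound 2 gives 4940 nM. Going by the values given here, the single measured step, a 2.9-fold lower number from compound 1 to compound 2 (0.46 log units; beyond the scatter), is the only comparison available, and it leaves compound 2 with the lower of the two numbers.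

Compound 3 `CC1CN(C(=O)c2c(N)sc(-c3ccc(Cl)cc3)c2-c2ccc(Cl)cc2)CCN1` changes the same position again: 3-methylpiperazin-1-yl in place of 2-oxopiperidin-1-yl on a carbonyl carbon. The change is the removal of a carbonyl-bearing ring in favour of a ring with a second nitrogen and a methyl. Among the compounds with values here, the measured step concerns the same ring but a different exchange, so it gives the direction only loosely; the group entering is not the one that left in compound 1. The expected step is therefore small, a 1.3-fold higher number from compound 2 to compound 3 (0.12 log units; within the scatter), within or just beyond the scatter. Compound 3 is estimated at 6500 nM, with a range from 2000 nM to 22000 nM.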

Compound 3, half-maximal inhibitory concentration: 7210 nM
For compound 3 the middle estimate is 1.1-fold (0.05 log units) below the measured one; measured number inside the range.
By their numbers in this assay, from the lowest: compounds 2, 3 and 1 (each within the scatter of the next, the first and the last beyond it).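

In this assay, putting a 3-methylpiperazin-1-yl on the carbonyl carbon in place of the 2-oxopiperidin-1-yl gives a 1.5-fold higher number from compound 2 to compound 3 (0.16 log units; within the scatter), so at this position a ring lacking the 2-oxo carbonyl can still read like compound 2. Set against the plain piperidin-1-yl, the same group gives a 2.0-fold lower number from compound 1 to compound 3 (0.30 log units; within the scatter), which means compound 3 cannot be told apart from either of the earlier compounds, even though those two stand apart by a 2.9-fold lower number from compound 1 to compound 2 (0.46 log units; beyond the scatter). Nothing on hand explains why these three rings give the numbers they do.

The compounds shown do not separate the effect of the methyl from that of the second ring nitrogen, and a plain piperazin-1-yl ring on the same carbonyl carbon would be needed to pull the two apart. They also leave open how a morpholine ring, or an open-chain amine such as diethylamino, would read at this position.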